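The source may hold more compounds than are shown below. What is called first, only, known or untested is meant among the compounds shown, and "the series" means these compounds.

Working notes on the series. Going by the values given here, compound 1 `CCOC(=O)C[C@H]1[C@@H](O[Si](C)(C)C(C)(C)C)[C@H](n2cnc3c(NC(=O)Nc4ccccc4)ncnc32)O[C@@H]1COC(=O)NC` and compound 2 `CNC(=O)NC[C@H]1O[C@@H](n2cnc3c(NC(=O)Nc4ccccc4)ncnc32)[C@H](O[Si](C)(C)C(C)(C)C)[C@@H]1CC(=O)N(C)OC` share a core and differ at two places, so no single step connects them. In a functional assay on 786-0 cells (Homo sapiens) for antiproliferative activity (on this read-out lower numbers stand for stronger inhibition of growth and higher numbers for weaker inhibition of growth), compound 1 gives 7.94 nM, and compound 2 gives 9.01 nM. Compound 2 has the higher of the two numbers, yet the gap to compound 1 lies within the scatter. Compound 3 `CCOC(=O)C[C@H]1[C@@H](O[Si](C)(C)C(C)(C)C)[C@H](n2cnc3c(NC(=O)Nc4ccccc4)ncnc32)O[C@@H]1CNC(=O)NC` is not yet measured; it differs from compound 2 by ethoxy in place of methoxy(methyl)amino on a carbonyl carbon. Among the compounds with values here, with no measured step for this change, no step beyond the scatter is expected, a 1.1-fold lower number from compound 2 to compound 3 (0.03 log units; within the scatter). In this assay compound 3 is estimated at 8.5 nM, range 4 nM to 18 nM.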

Compound 3, concentration for 50% growth inhibition: 2 nM
Compound 3: the middle estimate sits 4.3-fold (0.63 log units) above what was measured, and the stated range ends above it.
By their numbers in this assay, from the lowest: compound 3; then compounds 1 and 2 (each within the scatter of the next).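

In this assay ethoxy in place of methoxy(methyl)amino on a carbonyl carbon gives a 4.5-fold lower number from compound 2 to compound 3 (0.65 log units; beyond the scatter) and (methylcarbamoyl)amino in place of (methylcarbamoyl)oxy on a saturated chain carbon bound to a saturated ring carbon gives a 4.0-fold lower number from compound 1 to compound 3 (0.60 log units; beyond the scatter) as a second single step. Both places therefore bear on this read-out, which compound 1 and compound 2 could not show, as they differ at both places. No measured evidence bears on the reason for either step.

Open, from the compounds shown here alone, is how a carboxylic acid or a longer ester chain would read in place of the ethoxy group. Also open, going by these compounds, is whether a simple amine would hold the read-out in place of the (methylcarbamoyl)amino group.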